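This account rests on a few compounds, and the source may have more. Where it says the series, first, only, none or still open, it means among the compounds named here.

In a physicochemical assay for pharmacokinetics (on this read-out higher numbers stand for a longer-lived compound and lower numbers for a shorter-lived compound), compound 1 (`COc1cccc(CNC(=O)N2C(=O)c3ccccc3S2(=O)=O)c1`) gives > 166 h, which is a limit and not a number. Compound 2 (`O=C(NCc1ccccc1F)N1C(=O)c2ccccc2S1(=O)=O`) gives > 166 h, and this too is only a limit. The evidence so far is the limit of > 166 h in this assay, at which 2 of the 2 values shown sit. Compound 3 (`O=C(NCC1CCCCC1)N1C(=O)c2ccccc2S1(=O)=O`) has cyclohexyl in place of 2-fluorophenyl on the saturated chain carbon: cyclohexyl in place of 2-fluorophenyl on a saturated chain carbon bound to an amide-type nitrogen. For the measured compounds named here, the only measured step, a step that the two limits leave unreadable from compound 1 to compound 2, has no readable size, so no step beyond the scatter is expected. The estimated step is a step that the limit leaves unreadable from compound 2 to compound 3. The half-life expected for compound 3 is 200 h, within an estimated range of 90 h to 450 h.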

Compound 3, half-life: > 166 h
Compound 3: no number, only a limit (the forecaster's own chance of this, stated with the estimate: 70%); the middle value is on the limit's open side.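

For the compounds shown here, compound 1, compound 2 and compound 3 all give only limits in this assay, so no step among them can be read. On these data alone, their actual half-lives, and whether cyclohexyl, 2-fluorophenyl and 3-methoxyphenyl differ at all here, remain open.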